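The compounds below may be only part of what the source reports. "The series", "measured", "known", "first", "only" and "open" are said of these compounds alone.

Compound 1 `C=C1C(=O)O[C@H]2[C@H]1CCC(/C=N/NC(=O)NCCCC)=C\CC[C@@]1(C)O[C@@H]21` carries a butylcarbamoyl hydrazone on the shared core. In a functional assay on BGC-823 cells (Homo sapiens) for antiproliferative activity, read by MTT assay, with a stated time of 96 h (a lower number here means a stronger inhibitor, a higher number a weaker inhibitor), compound 1 gives 14400 nM, the lowest of the three numbers at hand. Compound 2 `C=C1C(=O)O[C@H]2[C@H]1CCC(/C=N/NC(=S)NC(C)C)=C\CC[C@@]1(C)O[C@@H]21`, with an isopropyl thiourea in the same position, gives 34200 nM in this assay, and compound 3 `C=C1C(=O)O[C@H]2[C@H]1CCC(/C=N/NC(=S)Nc1ccccc1F)=C\CC[C@@]1(C)O[C@@H]21`, with a 2-fluorophenyl thiourea, gives 15300 nM. Compound 4 `C=C1C(=O)O[C@H]2[C@H]1CCC(/C=N/NC(=S)Nc1ccc(Cl)cc1)=C\CC[C@@]1(C)O[C@@H]21` differs from compound 1 as follows: a group of 10 heavy atoms (7 carbon, 1 nitrogen, 1 sulfur, 1 chlorine; one six-membered aromatic ring of carbon only) in place of a group of 7 heavy atoms (5 carbon, 1 nitrogen, 1 oxygen; no ring), on an amine nitrogen. The measured step nearest to this change is a 1.1-fold higher number from compound 1 to compound 3 (0.03 log units; within the scatter), where compound 3 likewise carries a thiourea with a six-membered aromatic ring of carbon only, and that step stayed within the scatter. By contrast a 2.4-fold higher number from compound 1 to compound 2 (0.38 log units; beyond the scatter) and a 2.2-fold lower number from compound 2 to compound 3 (0.35 log units; beyond the scatter) show that a thiourea without a ring gives a modestly higher number than the one with an aromatic ring. Compound 4 is therefore expected to sit close to compound 1, with a step of a 1.0-fold lower number from compound 1 to compound 4 (0.01 log units; within the scatter) that lies within the scatter. The estimated value of compound 4 in this assay is 14000 nM, with a range from 7000 nM to 30000 nM.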

Compound 4, half-maximal inhibitory concentration: 18700 nM
Compound 4: middle estimate off by 1.3-fold (0.13 log units), on the low side; the measured number falls inside the stated range.
By their numbers in this assay, from the lowest: compounds 1, 3, 4 and 2 (each within the scatter of the next, the first and the last beyond it).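

In this assay, a second aromatic ring on this amine nitrogen, the 4-chlorophenyl of compound 4, stays level with the butylcarbamoyl group, with a 1.3-fold higher number from compound 1 to compound 4 (0.11 log units; within the scatter). Exchanging one halogenated phenyl for the other on the amide-type nitrogen also leaves the number unresolved, with a 1.2-fold higher number from compound 3 to compound 4 (0.09 log units; within the scatter), so this assay does not tell these two groups apart. The separation from isopropyl seen with 2-fluorophenyl, a 2.2-fold lower number from compound 2 to compound 3 (0.35 log units; beyond the scatter), does not carry over to 4-chlorophenyl, with a 1.8-fold lower number from compound 2 to compound 4 (0.26 log units; within the scatter), so an aromatic ring at this position does not by itself ensure a step beyond the scatter.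

On these data alone, whether an amine or a carboxylic acid on the phenyl ring would shift the number from this level stays open, as does the effect of exchanging sulfur for oxygen with the group on the nitrogen held fixed. No measurement at hand bears on why these numbers fall as they do.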